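Trifluoromethyl for Bromo at the Cytotoxicity Limit

This account rests on a few compounds, and the source may have more. Where it says the series, first, only, none or still open, it means among the compounds named here.

Measured compounds in an ADME assay on THP-1 cells (Homo sapiens) for cytotoxicity, read by WST assay, with a stated time of 24 h; a higher number here means a weaker inhibitor, a lower number a stronger inhibitor:
compound 1, `COc1cccc(NC(=O)c2ccc3cccc(O)c3n2)c1`, gives > 30000 nM, a limit of the assay.
compound 2, `O=C(Nc1cccc(Cl)c1)c1ccc2cccc(O)c2n1`, gives > 30000 nM, a limit of the assay.
compound 3, `O=C(Nc1cccc(Br)c1)c1ccc2cccc(O)c2n1`, gives > 30000 nM, a limit of the assay.

Compound 3 stands where the other two stand: at the limit of > 30000 nM in this assay, at which 3 of the 3 values shown sit. Its value is a limit and not a number, and the same holds for compound 1 and compound 2. With the limit of > 30000 nM in this assay, at which 3 of the 3 values shown sit, at both ends, the steps a step that the two limits leave unreadable from compound 1 to compound 2, a step that the two limits leave unreadable from compound 1 to compound 3 and a step that the two limits leave unreadable from compound 2 to compound 3 have no readable size or direction; they show only that exchanging methoxy, chloro and bromo on this aromatic carbon kept every compound at the limit.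

Compound 4, `O=C(Nc1cccc(C(F)(F)F)c1)c1ccc2cccc(O)c2n1`, differs from compound 3 by trifluoromethyl in place of bromo on an aromatic carbon. Going by the values given here, the steps that bear on this change are the three unreadable ones among compounds 1, 2 and 3, so they give no size to expect in this assay, in either direction. Compound 4 is therefore expected to remain at the limit, with the step that the limit leaves unreadable from compound 3 to compound 4 expected to stay within the scatter. The estimate for compound 4 is 40000 nM, with a range from 15000 nM to 120000 nM, and a limit rather than a number is the expected report.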

Compound 4, half-maximal inhibitory concentration: > 30000 nM
Compound 4: a limit, no number; the forecaster's own chance of this, stated with the estimate: 85%; the middle value does not contradict the limit.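

In this assay compound 4 gives > 30000 nM as a limit of the assay and not a number. Going by these compounds alone, no size or direction can be read for the steps joining compound 4 to compound 1, compound 2 or compound 3, so no new step emerges: the limit of > 30000 nM in this assay, at which 4 of the 4 values shown sit. The compounds shown leave open which change on this aromatic carbon, if any, would give a measurable value.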